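Ring-substituent change on the anilino group of compound 2

The source may hold more compounds than are shown below. What is called first, only, known or untested is meant among the compounds shown, and "the series" means these compounds.

Measured compounds:
compound 1 `C=CC(=O)Nc1cccc(NC(=O)CSc2nc(Nc3cccc(Br)c3)c3ccccc3n2)c1` — 15000 nM
compound 2 `C=CC(=O)Nc1cccc(NC(=O)CSc2nc(Nc3cccc(C)c3)c3ccccc3n2)c1` — 29200 nM

The series is read in a functional assay on PC-3 cells (Homo sapiens) for inhibition, read by MTT assay, with a stated time of 72 h; a lower number here means a stronger inhibitor, a higher number a weaker inhibitor. Compound 1 `C=CC(=O)Nc1cccc(NC(=O)CSc2nc(Nc3cccc(Br)c3)c3ccccc3n2)c1` gives 15000 nM in this assay, and compound 2 `C=CC(=O)Nc1cccc(NC(=O)CSc2nc(Nc3cccc(C)c3)c3ccccc3n2)c1` gives 29200 nM. Among the compounds with values here, the one step between them, a 1.9-fold higher number from compound 1 to compound 2 (0.29 log units; within the scatter), is a methyl in place of a bromo on an aromatic carbon, and it stays within the scatter, so the two compounds cannot be ranked against each other. Compound 2 stands with the highest number of the two, but only by a margin that the scatter covers.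

Compound 3 `C=CC(=O)Nc1cccc(NC(=O)CSc2nc(Nc3ccc(CC)cc3)c3ccccc3n2)c1` has not yet been measured. It differs from compound 2 by 4-ethylphenyl in place of 3-methylphenyl on a nitrogen on an aromatic ring. Within the data shown here, no measured step involves a change of this kind: the only step on record alters a single substituent on that ring without moving it, and that step was within the scatter. There is therefore no basis for expecting a shift beyond the scatter in either direction. Compound 3 is estimated at 30000 nM, with a range of 10000 nM to 90000 nM, and the expected step of a 1.0-fold higher number from compound 2 to compound 3 (0.01 log units; within the scatter) is accordingly close to flat.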

Compound 3, half-maximal inhibitory concentration: 24300 nM
Compound 3: middle estimate off by 1.2-fold (0.09 log units), on the high side; measured number inside the range.
By their numbers in this assay, from the lowest: compounds 1, 3 and 2 (each within the scatter of the next).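

Moving from 3-methylphenyl to 4-ethylphenyl on a nitrogen on an aromatic ring alters both the substituent and its place on the ring, yet in this assay the step stays within the scatter (a 1.2-fold lower number from compound 2 to compound 3 (0.08 log units; within the scatter)). The comparison with the bromo-bearing phenyl gives the same reading (a 1.6-fold higher number from compound 1 to compound 3 (0.21 log units; within the scatter)), so compounds 1, 2 and 3 cannot be ranked against one another, and none of the three groups on this nitrogen stands apart from the others in this assay. Together with the earlier step, this shows that a change in substituent, ring location and chain length at once still leaves the number within the scatter, and nothing available explains the small differences among these compounds.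

The compounds shown do not separate the contribution of the ethyl chain from that of its place on the ring, as the two change together in the one step. They also leave open whether an amine, a carboxylic acid or a longer chain such as hexyl on this phenyl ring would carry the number beyond the scatter in either direction.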